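The source may hold more compounds than are shown below. What is called first, only, known or untested is meant among the compounds shown, and "the series" means these compounds.

Among the two compounds measured so far, compound 2 `CN(Cc1cccs1)C1CCN(CCCc2c[nH]c3ccc(-n4cnnc4)cc23)CC1` stands lowest: in an assay on CHO cells for agonist activity at 5-hydroxytryptamine receptor 1D (Homo sapiens), read by GTPgammaS binding (on this read-out higher numbers stand for an effect only at larger amounts of compound and lower numbers for an effect already at smaller amounts), compound 2 gives 3.5 nM. Within the data shown here, its only neighbour, compound 1 `O=S(=O)(NCC1CCN(CCCc2c[nH]c3ccc(-n4cnnc4)cc23)CC1)c1ccccc1`, gives 12 nM in this assay, and the single measured step, a 3.4-fold lower number from compound 1 to compound 2 (0.54 log units; beyond the scatter), shows that swapping the group on this saturated ring carbon can move the number by a modest amount. Compound 3 `O[C@@H]1Cc2ccccc2[C@H]1NC1CCN(CCCc2c[nH]c3ccc(-n4cnnc4)cc23)CC1` is the next variation at the same place: (2-hydroxy-2,3-dihydro-1H-inden-1-yl)amino in place of methyl((thiophen-2-yl)methyl)amino on a saturated ring carbon. Among the measured compounds shown here, no measured pair covers this particular exchange, so the one step from compound 1 to compound 2 is the only guide, and it bears on it only in telling that the position tolerates quite different groups without large swings. Compound 3 is therefore expected to land near compound 2, at an estimated 5 nM with a range from 1.5 nM to 20 nM. The expected step is a 1.4-fold higher number from compound 2 to compound 3 (0.15 log units; within the scatter), within the scatter.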

Compound 3, half-maximal effective concentration: 13 nM
The estimate for compound 3 lay 2.6-fold (0.41 log units) below the measured number; the measured number falls inside the stated range.
By their numbers in this assay, from the lowest: compound 2; then compounds 1 and 3 (each within the scatter of the next).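

The exchange of methyl((thiophen-2-yl)methyl)amino for (2-hydroxy-2,3-dihydro-1H-inden-1-yl)amino gives a 3.7-fold higher number from compound 2 to compound 3 (0.57 log units; beyond the scatter), so this position does not treat all large amine groups alike. Set against ((phenylsulfonyl)amino)methyl, the same group gives a 1.1-fold higher number from compound 1 to compound 3 (0.03 log units; within the scatter), which places two quite different groups at one level and leaves compound 2 alone at the low end. Nothing shown here explains this difference.

Several things change together in the step to compound 3, including the ring types, the hydrogen-bond donors and the defined stereocentres, so the part that matters stays open. Going by these compounds, it also remains open whether a plain benzylamino group, or a (2,3-dihydro-1H-inden-1-yl)amino group without the hydroxy, would fall with compound 2 or with compound 3.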